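Changing the amide side chain of compound 3

This account rests on a few compounds, and the source may have more. Where it says the series, first, only, none or still open, it means among the compounds named here.

Measured so far in a functional assay on HepG2 cells (Homo sapiens) for antiproliferative activity, read by MTT assay, with a stated time of 48 h; a lower number here means a stronger inhibitor, a higher number a weaker inhibitor:
Compound 1 `CCn1c(C(=O)N(C)CC(=O)O)ccc1C(CC)(CC)c1ccc(OCCC(O)(CC)CC)c(C)c1` gives 5710 nM
Compound 2 `CCC(C)C(CO)NC(=O)c1ccc(C(CC)(CC)c2ccc(OCCC(O)(CC)CC)c(C)c2)n1CC` gives > 50000 nM, which is a limit of the assay and not a number
Compound 3 `CCn1c(C(=O)N(C)CCO)ccc1C(CC)(CC)c1ccc(OCCC(O)(CC)CC)c(C)c1` gives 510 nM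

Of the two true numbers, the lower belongs to compound 3. Compound 4 `CCn1c(C(=O)NC(CO)CCO)ccc1C(CC)(CC)c1ccc(OCCC(O)(CC)CC)c(C)c1` keeps the shared core and differs from compound 3 in one place: a group of 7 heavy atoms (4 carbon, 1 nitrogen, 2 oxygen; no ring) in place of a group of 5 heavy atoms (3 carbon, 1 nitrogen, 1 oxygen; no ring), on a carbonyl carbon, on a carbonyl carbon. All three measured steps changed this same place, and each lies beyond the scatter. One swap gave an 11-fold lower number from compound 1 to compound 3 (1.05 log units; beyond the scatter), and another gave an at least 8.7-fold higher number from compound 1 to compound 2 (0.94 log units; beyond the scatter). Compound 4 carries an amide hydrogen, as compound 2 does and compound 3 does not. Within the data shown here, that makes the closest guide, though only a single comparison, an at least 98-fold lower number from compound 2 to compound 3 (1.99 log units; beyond the scatter), a step that rests on a limit. A higher number is therefore expected in this assay, probably by less than that step. The expected change is a 4.9-fold higher number from compound 3 to compound 4 (0.69 log units; beyond the scatter) as an estimate. For compound 4 the estimated value is 2500 nM, with an expected range of 400 nM to 20000 nM.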

Compound 4, half-maximal inhibitory concentration: 24800 nM
Compound 4: the middle estimate sits 9.9-fold (1.00 log units) below what was measured, and the stated range ends below it.
By their numbers in this assay, from the lowest: compound 3; then compound 1; then compound 4. At a limit, above all of these: compound 2.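

A hydroxyl on the amide side chain is not enough to keep the number low: compound 4 carries hydroxyl groups too, yet the swap on the carbonyl carbon gives a 49-fold higher number from compound 3 to compound 4 (1.69 log units; beyond the scatter). The same compound also falls behind the carboxylic acid of the series, with a 4.3-fold higher number from compound 1 to compound 4 (0.64 log units; beyond the scatter), so compound 3 remains the only side chain here with a number well under the others. The step of an at least 2.0-fold lower number from compound 2 to compound 4 (0.30 log units; that floor lies within the scatter) starts from a limit of the assay, not a number, and fixes no order: the limit of > 50000 nM in this assay, at which 1 of the 4 values shown sits.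

Compound 4 gains an amide hydrogen and a second hydroxyl-bearing chain in one swap, so the compounds shown cannot say which of the two goes with the higher number. Also open, on these data alone, is how an amine, or a longer hydroxyalkyl chain on the methyl-bearing amide nitrogen, would fare at this position.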